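The compounds below may be only part of what the source reports. "The series", "measured", "known", "first", "only" and "open" are said of these compounds alone.

Measured so far:
compound 1, `COC1(c2cc(F)cc(OCc3ccc(-n4ccnc4C)cc3)c2)CCOCC1`, gives 2 mg/kg
compound 2, `Cc1nccn1-c1ccc(COc2cc(F)cc(C3(C(N)=O)CCOCC3)c2)cc1`, gives 4.9 mg/kg
compound 3, `CNC(=O)C1(c2cc(F)cc(OCc3ccc(-n4ccnc4C)cc3)c2)CCOCC1`, gives 13 mg/kg

In a functional assay on the whole organism for activation, with Mus musculus as the target (a higher number here means that more compound is needed for the effect, a lower number that less compound is needed), compound 3 stands highest of the three, so it needs the most material for the effect. The distance is set by a 6.5-fold higher number from compound 1 to compound 3 (0.81 log units; beyond the scatter) and by a 2.7-fold higher number from compound 2 to compound 3 (0.42 log units; beyond the scatter), both beyond the scatter. Compound 4, `CSC1(c2cc(F)cc(OCc3ccc(-n4ccnc4C)cc3)c2)CCOCC1`, is the next step: methylsulfanyl in place of methylcarbamoyl on a saturated ring carbon.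

The measured steps that bear on this change start from compound 1: a 6.5-fold higher number from compound 1 to compound 3 (0.81 log units; beyond the scatter) shows that placing methylcarbamoyl where methoxy sat raised the number, and a 2.5-fold higher number from compound 1 to compound 2 (0.39 log units; beyond the scatter) shows a smaller rise with carbamoyl. Methylsulfanyl, like methoxy, brings no hydrogen-bond donor and one hydrogen-bond acceptor, so compound 4 is expected to move back toward compound 1 rather than further up; the expected step is a 4.3-fold lower number from compound 3 to compound 4 (0.64 log units; beyond the scatter). The number for compound 4 in this assay is estimated at 3 mg/kg, within a range from 1.5 mg/kg to 8 mg/kg.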

Compound 4, dose for half-maximal effect: 5 mg/kg
Compound 4: middle estimate off by 1.7-fold (0.22 log units), on the low side, and the stated range covers the measured number.
By their numbers in this assay, from the lowest: compound 1; then compounds 2 and 4 (each within the scatter of the next); then compound 3.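

In this assay, methylsulfanyl on this saturated ring carbon gives a 2.6-fold lower number from compound 3 to compound 4 (0.41 log units; beyond the scatter), yet it still does not match methoxy, with a 2.5-fold higher number from compound 1 to compound 4 (0.40 log units; beyond the scatter), so two groups that each bring no hydrogen-bond donor and one acceptor are not interchangeable here. Methylsulfanyl also sits level with the unsubstituted amide, with a 1.0-fold higher number from compound 2 to compound 4 (0.01 log units; within the scatter), so at this position the counts of donors and acceptors alone do not set the dose needed. Nothing available explains these differences between the groups.

The compounds shown leave open whether a longer chain, such as ethoxy or ethylsulfanyl, would stay close to compound 1 or move away from it. They also leave open where a hydroxyl or an amine on the same ring carbon would fall.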